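The compounds below may be only part of what the source reports. "The series", "measured", "known", "first", "only" and "open" are said of these compounds alone.

Measured in an ADME assay on microsomes from liver (Rattus norvegicus) for metabolic stability, read by LC-MS, with a stated time of 1 h, at 37 degrees C, tested at 4 uM; a lower number here means that less of the compound is left, a higher number that more of the compound is left:
Compound 1 `O=C(O)c1cc(-c2cccc(COc3ccc4c(=O)n(CC5CC5)sc4c3)c2)ccc1Cl`: 75%
Compound 2 `O=C1c2ccc(OCc3cccc(-c4ccccc4)c3)cc2CN1C1CCCC1`: 38%
Compound 3 `O=C1c2ccc(OCc3cccc(-c4ccc(C(F)(F)F)cc4F)c3)cc2CN1C1CCCC1`: "not determined" (no result reported)

Compound 1 stands highest of the two numbers available, beyond the scatter from compound 2, its nearest neighbour, while compound 3 has no number reported.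

Compound 4 `CC(C)CCn1sc2cc(OCc3cccc(-c4ccc(Cl)c(C(=O)O)c4)c3)ccc2c1=O`, not yet measured, departs from compound 1 by one change: isobutyl in place of cyclopropyl on a saturated chain carbon bound to an aromatic nitrogen. This puts isobutyl in place of cyclopropyl on a saturated chain carbon bound to an aromatic nitrogen.

Going by the values given here, no measured pair differs in one place, so no direct precedent exists. A small downward step in this assay, not clearly beyond the scatter, is expected. The expected change is a number 10 percentage points lower from compound 1 to compound 4 (within the scatter). For compound 4 the estimated value is 65%, with an expected range from 42% to 82%.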

Compound 4, percent of the compound remaining: 92%
Estimate against measurement, compound 4: 27 percentage points below; the whole stated range lies below it.
By their numbers in this assay, from the lowest: compound 2; then compound 1; then compound 4.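

Exchanging cyclopropyl for isobutyl on a saturated chain carbon bound to an aromatic nitrogen gives, in this assay, a number 17 percentage points higher from compound 1 to compound 4 (beyond the scatter). This is the first single change shown at this position, and it shows that the three-membered ring can give way to an open chain there without any loss in the compound remaining. Nothing available explains the step. The compounds shown leave open how a longer chain, an amine or a carboxylic acid at this position would fare. As far as these compounds go, whether the same exchange would give a similar step on another core also stays open.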